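The source may report more compounds than this note shows. Statements on the series, on what has been measured and on what is new or still open speak of the compounds shown alone.

Among the measured compounds shown here, compound 2 `O=C(Nc1cccc(I)c1)C(Cl)Cl` gives 4760 nM in a functional assay on A549 cells (Homo sapiens) for antiproliferative activity, read by MTT assay, with a stated time of 72 h (a higher number here means a weaker inhibitor, a lower number a stronger inhibitor), the lowest of the two numbers so far; compound 1 `O=C(Nc1cccc(Cl)c1)C(Cl)Cl` gives 14800 nM, and the step of a 3.1-fold lower number from compound 1 to compound 2 (0.49 log units; beyond the scatter) is the only one measured. Compound 3 `O=C(Nc1cccc(SC(F)(F)F)c1)C(Cl)Cl` differs from compound 2 by (trifluoromethyl)sulfanyl in place of iodo on an aromatic carbon. For the measured compounds named here, no measured step exchanges iodo for (trifluoromethyl)sulfanyl, so the chloro-to-iodo step is the only guide and bears on this change only loosely. A step within or near the scatter is therefore expected, a 1.1-fold higher number from compound 2 to compound 3 (0.02 log units; within the scatter). Compound 3 is estimated at 5000 nM, with a range of 1500 nM to 16000 nM.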

Compound 3, half-maximal inhibitory concentration: 14100 nM
Beside the measured number, compound 3's estimate is 2.8-fold (0.45 log units) below it, within the range that was stated.
By their numbers in this assay, from the lowest: compound 2; then compounds 3 and 1 (each within the scatter of the next).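

In this assay, (trifluoromethyl)sulfanyl in place of iodo gives a 3.0-fold higher number from compound 2 to compound 3 (0.47 log units; beyond the scatter), so the lower number seen with iodo does not carry over to this group of 5 heavy atoms. Against chloro, the same group gives a 1.0-fold lower number from compound 1 to compound 3 (0.02 log units; within the scatter), which leaves iodo alone apart among the three substituents at this position. Nothing available bears on why iodo differs from the other two. Open, from the compounds shown here alone, is how an amine, a carboxylic acid or a methoxy group would read at this position. Also open, going by these compounds, is whether the iodo result holds with changes elsewhere on the shared core.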